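This account rests on a few compounds, and the source may have more. Where it says the series, first, only, none or still open, it means among the compounds named here.

Measured so far:

Compound 1, `O=c1n(Cc2cc3cnccc3n2CCCC(F)(F)F)c2cnccc2n1C1CC1`, gives > 50000 nM in an ADME assay on HeLa cells (Homo sapiens) for cytotoxicity, read by ATP content, with a stated time of 3 days; a higher number here means that more compound is tolerated, a lower number that less compound is tolerated; this value is a limit of the assay, not a number.

Compound 2, `CS(=O)(=O)CCCn1c(Cn2c(=O)n(CC#N)c3ccncc32)cc2cc(Cl)ccc21`, gives > 50000 nM in this assay; this value is also a limit.

Compound 3, `Cn1ccc(-n2c(=O)n(Cc3cc4cc(Cl)ccc4n3CCCC#N)c3cnccc32)n1`, gives > 50000 nM in this assay; this value is likewise a limit.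

Compound 3 therefore has no measured number to stand on. It sits at the limit of > 50000 nM in this assay, at which 3 of the 3 values shown sit. For the measured compounds named here, with all three values at the same limit, no order among compounds 1, 2 and 3 can be read, and no step between any two of them is known in this assay.

The next compound in the series is compound 4, `COc1ccc(-n2c(=O)n(Cc3cc4cc(Cl)ccc4n3CCCC#N)c3cnccc32)cc1C`. It differs from compound 3 in one place: 4-methoxy-3-methylphenyl in place of 1-methyl-1H-pyrazol-3-yl on an aromatic nitrogen. The rest of the shared core is kept.

Going by the values given here, since every measured value in this assay is a limit, there is no measured step of any size from which to scale this change. The expectation is that the step in this assay is none beyond the scatter, with compound 4 also landing at the limit rather than at a number. The expected step is a step that the limit leaves unreadable from compound 3 to compound 4.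

Compound 4 is expected to give about 60000 nM in this assay, with a range of 30000 nM to 150000 nM.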

Compound 4, half-maximal cytotoxic concentration: > 50000 nM
Compound 4: no number, only a limit; the forecaster's own chance of this, stated with the estimate: 80%; the middle value is on the limit's open side.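

No step can be read between compound 3 and compound 4 in this assay, as both values are limits and not numbers: the limit of > 50000 nM in this assay, at which 4 of the 4 values shown sit. The compounds shown leave open where a measured half-maximal cytotoxic concentration would lie for any of them, and whether 4-methoxy-3-methylphenyl in place of 1-methyl-1H-pyrazol-3-yl changes it at all.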